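From 4-chlorophenyl to 3,4-dichlorophenyl: compound 1 and compound 4

A few compounds are considered here, and "the series" means these few. Any claim that something is new, unique, unknown or untested is made for them only; others in the source may bear on it.

Of the compounds shown here, three have been read in a functional assay on HepG2 cells (Homo sapiens) for cytotoxicity; a higher number here means a weaker inhibitor, a lower number a stronger inhibitor. Compound 1 `Cc1c(S(=O)(=O)N/C(=N\O)Nc2ccc(Cl)cc2)sc2ccc(Cl)cc12` gives 140 ug/mL, the highest of the two actual numbers. The nearest number comes from compound 3 `CCCCOc1ccc(S(=O)(=O)N/C(=N\O)Nc2ccc(Cl)cc2)cc1` at 63 ug/mL, lower by more than the usual scatter. In this assay compound 2 `O=S(=O)(N/C(=N\O)Nc1ccc(Cl)cc1)c1cc2ccccc2o1` reads > 200 ug/mL, which is a limit of the assay and not a number.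

The next compound is compound 4 `Cc1c(S(=O)(=O)N/C(=N\O)Nc2ccc(Cl)c(Cl)c2)sc2ccc(Cl)cc12`, with chloro in place of hydrogen on an aromatic carbon. The added chloro stands ortho to a chloro group and meta to a large group, so 4-chlorophenyl becomes 3,4-dichlorophenyl. Among the measured compounds shown here, no measured pair shows this change, or any other single change, so the expectation rests on only three compounds that differ elsewhere in their structures. A small move towards a lower number in this assay is expected, within the scatter or close to it. The expected step is a 1.6-fold lower number from compound 1 to compound 4 (0.19 log units; within the scatter). For compound 4 the estimated value is 90 ug/mL, with an expected range of 40 ug/mL to 190 ug/mL.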

Compound 4, half-maximal inhibitory concentration: > 300 ug/mL
Compound 4: a limit, no number; the forecaster's own chance of this, stated with the estimate: 7%; at least 3.3-fold (0.52 log units) between middle value and limit.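

In this assay compound 4 reads > 300 ug/mL, which is a limit of the assay and not a number. Chloro in place of hydrogen on an aromatic carbon, ortho to a chloro group and meta to a large group, gives an at least 2.1-fold higher number from compound 1 to compound 4 (0.33 log units; beyond the scatter), the first single-place step in the series, and it shows that at this position the added chloro goes with a higher number, meaning a weaker inhibitor, and not with a lower one. Only the direction and a minimum size of this step can be read, since compound 4 sits at a limit: the limit of > 300 ug/mL in this assay, at which 1 of the 4 values shown sits.

Whether 4-chlorophenyl to 3,4-dichlorophenyl moves the reading the same way on compound 2 or compound 3 remains open, as this single pair carries the whole observation and says nothing about what lies behind it. Also open, from the compounds shown here alone, is how the series reads with an amine, a methoxy group or a carboxylic acid in place of the added chloro, so the step cannot yet be assigned to chloro in particular or to any group at this position.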